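The source may report more compounds than this note shows. Statements on the series, on what has been measured and on what is new or still open speak of the compounds shown alone.

Compound 1 `N#Cc1cc2c(nc1N1CCC(C(=O)NS(=O)(=O)Cc3cc(Cl)cc(Cl)c3)CC1)COC2=O` was tested in a functional assay (Platelet, plasma) for inhibition, with Homo sapiens as the target (a higher number here means a weaker inhibitor, a lower number a stronger inhibitor), where compound 1 gave 30500 nM. A second compound with the same core, compound 2 `CC1(C(=O)NS(=O)(=O)Cc2ccc(F)cc2)CCN(c2nc3c(cc2C#N)C(=O)OC3)CC1`, gave 35400 nM in this assay. These two numbers sit within the usual scatter of each other, so compound 1 and compound 2 cannot be told apart as inhibitors; compound 1 simply has one of the two numbers that were obtained at all. Compound 3 `N#Cc1cc2c(nc1N1CC(C(=O)NS(=O)(=O)Cc3ccccc3)C1)COC2=O` is different: in this assay compound 3 reached only > 300000 nM, which is a limit of the assay rather than a number (the limit of > 300000 nM in this assay, at which 1 of the 3 values shown sits).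

Compound 4 `N#Cc1cc2c(nc1N1CCC(C(=O)NS(=O)(=O)Cc3ccc(C(F)(F)F)cc3)CC1)COC2=O` is not yet measured. It differs from compound 1 in a single place: 4-(trifluoromethyl)phenyl in place of 3,5-dichlorophenyl on a saturated chain carbon bound to a sulfonyl sulfur. Going by the values given here, no measured pair shows what such an exchange of one substituted benzyl group for another does to this assay, so there is no step to lean on; the two halogen-bearing benzyl groups of compound 1 and compound 2 gave numbers within the scatter of each other, and the trifluoromethyl group of compound 4 is taken here to behave much the same way. The expected step of a 1.3-fold higher number from compound 1 to compound 4 (0.12 log units; within the scatter) is therefore small, at most a mild weakening. For compound 4 the estimate in this assay is 40000 nM, with a likely range from 12000 nM to 130000 nM.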

Compound 4, half-maximal inhibitory concentration: 15900 nM
For compound 4 the middle estimate is 2.5-fold (0.40 log units) above the measured one; the measured number falls inside the stated range.
By their numbers in this assay, from the lowest: compounds 4, 1 and 2 (each within the scatter of the next, the first and the last beyond it). At a limit, above all of these: compound 3.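

In this assay, going by these compounds alone, the exchange of 3,5-dichlorophenyl for 4-(trifluoromethyl)phenyl gives a 1.9-fold lower number from compound 1 to compound 4 (0.28 log units; within the scatter), which is the first direct reading of a change at this position with the rest of the molecule held fixed. The assay therefore cannot tell these two groups apart, even though the entering group has 10 heavy atoms against 8 for the leaving one and carries fluorine in place of chlorine, so this position accepts at least this one exchange without a change that stands clear of the scatter. Within the data shown here, nothing measured so far offers a reason for this outcome, and a step this small does not call for one.

Going by these compounds, both groups compared here are halogen-bearing aromatic rings on the same saturated chain carbon, so it remains open whether an amine or a carboxylic acid on that ring would leave the number equally undisturbed. On these data alone, it is equally open what a longer chain between the sulfonyl sulfur and the ring would do, since a single pair cannot show how far this tolerance extends.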